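Lengthening the chain behind the amide linker

The compounds below may be only part of what the source reports. "The series", "measured", "known", "first", "only" and "open" are said of these compounds alone.

Measured compounds:
Compound 1, `CN(C)C(=O)c1cc2cnc(Nc3ccc(S(=O)(=O)NCCCCCN=C=S)cc3)nc2n1C1CCCC1`, in a functional assay on A549 cells (Homo sapiens) for inhibition, read by CCK-8 assay, with a stated time of 72 h, tested at 10 uM (a lower number here means a weaker effect, a higher number a stronger effect of the compound at the concentration tested), compound 1 gives 102%.
Compound 2, `CN(C)C(=O)c1cc2cnc(Nc3ccc(S(=O)(=O)NCCCCCCCN=C=S)cc3)nc2n1C1CCCC1`; in this assay compound 2 gives 101%.
Compound 3, `CN(C)C(=O)c1cc2cnc(Nc3ccc(C(=O)NCCCN=C=S)cc3)nc2n1C1CCCC1`; in this assay compound 3 gives 103%.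

All three compounds share one core and differ only in the linker on the aromatic ring and in the length of the chain that carries the isothiocyanate. Compound 3 holds the highest of the three numbers, but none of the gaps reaches beyond the scatter: a number 1 percentage points higher from compound 1 to compound 3 (within the scatter), and the values of compound 2 and compound 3 also sit within the scatter of each other. In practice the three are indistinguishable in this assay.

Compound 4, `CN(C)C(=O)c1cc2cnc(Nc3ccc(C(=O)NCCCCCCCN=C=S)cc3)nc2n1C1CCCC1`, has not been measured yet. It differs from compound 3 in one place: a group of 7 heavy atoms (5 carbon, 1 nitrogen, 1 sulfur; no ring) in place of a group of 3 heavy atoms (1 carbon, 1 nitrogen, 1 sulfur; no ring), on a saturated chain carbon, three bonds along the chain from an amide-type nitrogen.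

Within the data shown here, one measured step bears on this change. Between compound 1 and compound 2 the chain behind the sulfonamide nitrogen was lengthened in a comparable way, and the result was a number 1 percentage points lower from compound 1 to compound 2 (within the scatter). Since that lengthening left the read-out unchanged, the same is expected here: the estimated step is a number 2 percentage points lower from compound 3 to compound 4 (within the scatter), no step beyond the scatter. Compound 4 is therefore expected to give about 101%, within a range from 94% to 106%.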

Compound 4, a percentage reported as inhibition, at one concentration (the size of the read-out at that concentration, not a potency): 101%
Compound 4: the middle estimate sits on the measured number at the digits printed; measured number inside the range.
By their numbers in this assay, from the lowest: compounds 2, 4, 1 and 3 (each within the scatter of the next).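

With the amide linker, a saturated chain carbon three bonds along the chain from an amide-type nitrogen can carry the group of 7 heavy atoms in place of the group of 3 heavy atoms with no change beyond the scatter in this assay (a number 2 percentage points lower from compound 3 to compound 4 (within the scatter)). Until now, a longer chain had been compared only behind the sulfonamide nitrogen (a number 1 percentage points lower from compound 1 to compound 2 (within the scatter)), so compounds 3 and 4 extend that observation to a second linker, and across these two pairs chain length leaves the read-out within the scatter. Nothing available here gives a reason for this tolerance of the longer chain.

All four numbers lie close to full inhibition at a single concentration, so any difference in potency between the short and long chains could remain hidden, and a series of lower concentrations would be needed to reveal it. Also open, from the compounds shown here alone, is whether the read-out would hold with an amine or a carboxylic acid in place of the isothiocyanate at the end of the chain, which would show whether that end group matters at all.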